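Dropping the trifluoromethyl from the benzamide of compound 1

The source may report more compounds than this note shows. Statements on the series, on what has been measured and on what is new or still open speak of the compounds shown alone.

Compounds measured so far:
compound 1 `COc1cc(-c2nn(-c3cccc(NC(=O)c4cccc(C(F)(F)F)c4)c3)cc2-c2ccncc2)ccc1Cl`, 2240 nM
compound 2 `O=C(Nc1cccc(-n2cc(-c3ccncc3)c(-c3ccc(Cl)c(O)c3)n2)c1)Nc1cc(C(F)(F)F)cc(C(F)(F)F)c1`, 1030 nM

In a functional assay on HCC 2998 cells (Homo sapiens) for inhibition, read by sulforhodamine B assay, with a stated time of 48 h (a higher number here means a weaker inhibitor of growth, a lower number a stronger inhibitor of growth), compound 1 gives 2240 nM, the highest of the two numbers recorded. Its nearest neighbour, compound 2, gives 1030 nM, a lower number by a margin that lies beyond the usual scatter; the two compounds differ in more than one place, so the comparison says only what their two values show.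

Compound 3 `COc1cc(-c2nn(-c3cccc(NC(=O)c4ccccc4)c3)cc2-c2ccncc2)ccc1Cl` has not yet been measured. It differs from compound 1 in one place: hydrogen in place of trifluoromethyl on an aromatic carbon. Among the compounds with values here, no pair of measured compounds shows the effect of this change, so the direction rests on general experience with amides of this type. Compound 3 is expected to be a somewhat weaker inhibitor of growth than compound 1, a step of a 2.2-fold higher number from compound 1 to compound 3 (0.35 log units; beyond the scatter) in this assay. Compound 3 is therefore estimated at 5000 nM, within a range of 1800 nM to 14000 nM.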

Compound 3, concentration for 50% growth inhibition: 2320 nM
Compound 3: the middle estimate sits 2.2-fold (0.33 log units) above what was measured, and the stated range covers the measured number.
By their numbers in this assay, from the lowest: compound 2; then compounds 1 and 3 (each within the scatter of the next).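

In this assay, hydrogen in place of trifluoromethyl on this aromatic carbon gives a 1.0-fold higher number from compound 1 to compound 3 (0.02 log units; within the scatter). Within the data shown here, this is the first pair that isolates a single change, and it shows that 3-(trifluoromethyl)phenyl and phenyl cannot be told apart at this place on the benzamide of compound 1: the trifluoromethyl is not required for the growth inhibition read here. No measurement to hand bears on why the two compounds read alike.

Going by these compounds, it remains open whether another group on this same aromatic carbon, such as an amine or a carboxylic acid, would shift the number. Also open, on these data alone, is whether the same exchange would read alike on the urea of compound 2, which differs from compound 1 in more than one place.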